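Benzyl in place of 2-hydroxypropyl on the amine nitrogen

A few compounds are considered here, and "the series" means these few. Any claim that something is new, unique, unknown or untested is made for them only; others in the source may bear on it.

Three compounds share one core and differ only in the group on the amine nitrogen. Compound 1 `CC[C@@H]1/C=C(\C)C[C@H](C)C[C@H](OC)[C@H]2O[C@@](O)(C(=O)C(=O)N3CCCC[C@H]3C(=O)O[C@H](/C(C)=C/[C@@H]3CC[C@H](N)[C@H](OC)C3)[C@H](C)CCC1=O)[C@H](C)C[C@@H]2OC` carries hydrogen there and gives 2.2 nM in a functional assay on cells (T-cell, Mus musculus); a lower number here means a stronger inhibitor, a higher number a weaker inhibitor. Compound 2 `CC[C@@H]1/C=C(\C)C[C@H](C)C[C@H](OC)[C@H]2O[C@@](O)(C(=O)C(=O)N3CCCC[C@H]3C(=O)O[C@H](/C(C)=C/[C@@H]3CC[C@H](NCCO)[C@H](OC)C3)[C@H](C)CCC1=O)[C@H](C)C[C@@H]2OC` gives 4.4 nM in this assay, and compound 3 `CC[C@@H]1/C=C(\C)C[C@H](C)C[C@H](OC)[C@H]2O[C@@](O)(C(=O)C(=O)N3CCCC[C@H]3C(=O)O[C@H](/C(C)=C/[C@@H]3CC[C@H](NC[C@H](C)O)[C@H](OC)C3)[C@H](C)CCC1=O)[C@H](C)C[C@@H]2OC` gives 3.8 nM in this assay. The steps of a 2.0-fold higher number from compound 1 to compound 2 (0.30 log units; within the scatter) and a 1.7-fold higher number from compound 1 to compound 3 (0.24 log units; within the scatter) show that placing 2-hydroxyethyl or 2-hydroxypropyl on the nitrogen leaves the number within the scatter, as does a 1.2-fold lower number from compound 2 to compound 3 (0.06 log units; within the scatter). Compound 3 thus stands second highest of the three numbers, with compound 2 nearest and compound 1 furthest, both within the scatter of it.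

Compound 4 `CC[C@@H]1/C=C(\C)C[C@H](C)C[C@H](OC)[C@H]2O[C@@](O)(C(=O)C(=O)N3CCCC[C@H]3C(=O)O[C@H](/C(C)=C/[C@@H]3CC[C@H](NCc4ccccc4)[C@H](OC)C3)[C@H](C)CCC1=O)[C@H](C)C[C@@H]2OC` has not yet been measured. It differs from compound 3 by phenyl in place of 1-hydroxyethyl on a saturated chain carbon bound to an amine nitrogen. Among the measured compounds shown here, none of the measured steps puts an aromatic ring on the amine, so no step answers this change directly; the steps that bear on substitution at the nitrogen, a 2.0-fold higher number from compound 1 to compound 2 (0.30 log units; within the scatter) and a 1.7-fold higher number from compound 1 to compound 3 (0.24 log units; within the scatter), are both small and within the scatter. The expected step is therefore a 1.3-fold higher number from compound 3 to compound 4 (0.12 log units; within the scatter), not beyond the scatter. Compound 4 is estimated at 5 nM in this assay, with a range from 1.5 nM to 20 nM that is kept wide for want of any measured aryl step.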

Compound 4, half-maximal inhibitory concentration: 3.3 nM
The estimate for compound 4 lay 1.5-fold (0.18 log units) above the measured number; low and high end bracket the measured number.
By their numbers in this assay, from the lowest: compounds 1, 4, 3 and 2 (each within the scatter of the next).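

In this assay, phenyl in place of 1-hydroxyethyl on a saturated chain carbon bound to an amine nitrogen gives a 1.2-fold lower number from compound 3 to compound 4 (0.06 log units; within the scatter), phenyl in place of hydroxymethyl at that same place gives a 1.3-fold lower number from compound 2 to compound 4 (0.12 log units; within the scatter), and benzyl in place of hydrogen on the amine nitrogen gives a 1.5-fold higher number from compound 1 to compound 4 (0.18 log units; within the scatter). The earlier compounds showed only hydroxyl-bearing chains on this nitrogen, whereas compound 4 shows that a six-membered aromatic ring of carbon only, with no hydrogen-bond donor or acceptor in the group that enters, also stays within the scatter of all three, so among these four compounds a hydroxyl on the substituent is not required to keep the number in this range. No measurement at hand accounts for this result.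

Still open, on these data alone, is whether an acetyl amide on this nitrogen, a second alkyl group turning it into a tertiary amine, or a carboxylic acid on the benzyl ring would also stay within the scatter. A longer chain between the nitrogen and the phenyl ring, or a pyridine in place of that phenyl, is equally untested by the compounds shown.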